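This account rests on a few compounds, and the source may have more. Where it says the series, first, only, none or still open, it means among the compounds named here.

Measured so far in an assay on Sf9 cells for inhibition of 1-acyl-sn-glycerol-3-phosphate acyltransferase beta (Homo sapiens); a lower number here means a stronger inhibitor, a higher number a weaker inhibitor:
Compound 1 `CCOc1ccc(Br)cc1-c1cc(Nc2ccc(B(O)O)cc2)nc(N)n1` gives 91 nM.
Compound 2 `CCOc1ccc(Br)cc1-c1cc(Nc2ccc(C(=N)N)cc2)nc(N)n1` gives > 5000 nM, which is a limit of this assay rather than a number.

Compound 2 thus stands at the limit of this assay, with only > 5000 nM known for it, as the limit of > 5000 nM in this assay, at which 1 of the 2 values shown sits, records. Compound 3 `CCOc1ccc(Br)cc1-c1cc(Nc2ccccc2)nc(N)n1` differs from compound 2 by a hydrogen atom in place of a group of 3 heavy atoms (1 carbon, 2 nitrogen; no ring), on an aromatic carbon. For the measured compounds named here, one measured step bears on this position: an at least 54-fold higher number from compound 1 to compound 2 (1.73 log units; beyond the scatter). Going by the values given here, the group that leaves in compound 3 is the one whose entry in compound 2 went with that large step, while no measured compound carries a hydrogen here, so the size of the change is uncertain. A fall from the limit is expected, though a number weaker than that of compound 1 remains likely. Compound 3 is therefore estimated at 1000 nM, between 150 nM and 8000 nM. This estimate means an expected step of an at least 5.0-fold lower number from compound 2 to compound 3 (0.69 log units; beyond the scatter).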

Compound 3, half-maximal inhibitory concentration: 120 nM
Beside the measured number, compound 3's estimate is 8.3-fold (0.92 log units) above it; measured number outside the range, below it.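

In this assay, a hydrogen atom in place of the group of 3 heavy atoms with 1 carbon and 2 nitrogen gives an at least 41-fold lower number from compound 2 to compound 3 (1.61 log units; beyond the scatter) in going back from that group, so the large loss goes with the entry of this group and not with the departure of the group of 1 boron and 2 oxygen. The second comparison, a 1.3-fold higher number from compound 1 to compound 3 (0.12 log units; within the scatter) for a hydrogen atom in place of the boron-bearing group, shows that in this series compound 1 needs that group for no measurable part of its number. On these data alone, compound 2 carries only a limit, so the true size of its step remains unknown: the limit of > 5000 nM in this assay, at which 1 of the 3 values shown sits.

As far as these compounds go, whether an amine or a carboxylic acid on this aromatic carbon would stay with compound 3 or fall toward compound 2 stays open. So does whether a hydroxyl or a methoxy group here would change the number at all.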